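This account rests on a few compounds, and the source may have more. Where it says the series, first, only, none or still open, it means among the compounds named here.

Notes on the series. Compound 1 `CCC(=O)N1CCC(NS(=O)(=O)c2ccc(NC(=O)c3ccccc3C)c3ccccc23)CC1` gives 2.5 nM in an assay on L1.2 cells for binding affinity to C-C chemokine receptor type 8 (Homo sapiens); on this read-out higher numbers stand for weaker inhibition and lower numbers for stronger inhibition. Compound 2 `CC(=O)N1CCC(NS(=O)(=O)c2ccc(NC(=O)c3ccccc3C)c3ccccc23)CC1` gives 6.7 nM in this assay, the step of a 2.7-fold higher number from compound 1 to compound 2 (0.43 log units; beyond the scatter). Compound 3 `Cc1ccccc1C(=O)Nc1ccc(S(=O)(=O)NC2CCN(C(=O)C3CNC3)CC2)c2ccccc12` gives 1.5 nM in this assay; the step of a 1.7-fold lower number from compound 1 to compound 3 (0.22 log units; within the scatter) stays within the scatter, while a 4.5-fold lower number from compound 2 to compound 3 (0.65 log units; beyond the scatter) is a modest gain, so compound 3 holds the lowest number of the three but is not separated from compound 1.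

Compound 4 `CCCNC(=O)N1CCC(NS(=O)(=O)c2ccc(NC(=O)c3ccccc3C)c3ccccc23)CC1` differs from compound 3 by propylamino in place of azetidin-3-yl on a carbonyl carbon. All three measured steps concern the same carbonyl substituent and span only modest sizes, so the change in this assay is expected to be small, with a slight loss more likely than a gain: a 2.7-fold higher number from compound 3 to compound 4 (0.43 log units; beyond the scatter). Compound 4 is estimated at 4 nM in this assay, within 1.5 nM to 12 nM.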

Compound 4, inhibition constant: 77.4 nM
For compound 4 the middle estimate is 19-fold (1.29 log units) below the measured one; the measured number lies above the stated range.
By their numbers in this assay, from the lowest: compounds 3 and 1 (each within the scatter of the next); then compound 2; then compound 4.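

At the carbonyl carbon bound to the amide-type ring nitrogen, the substituent can shift the number far more than the methyl, ethyl and azetidin-3-yl steps suggested: in this assay propylamino gives the large steps (a 52-fold higher number from compound 3 to compound 4 (1.71 log units; beyond the scatter)) and (a 12-fold higher number from compound 2 to compound 4 (1.06 log units; beyond the scatter)) and (a 31-fold higher number from compound 1 to compound 4 (1.49 log units; beyond the scatter)). Heavy-atom count does not separate propylamino from azetidin-3-yl, which has the same count, so this count alone does not track the change. Nothing available explains the loss.

Propylamino differs from azetidin-3-yl both in having no ring and in placing its nitrogen on the carbonyl carbon, and these compounds do not separate the two. Azetidin-1-yl or butyl on the same carbonyl carbon would address that question.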